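A few compounds are considered here, and "the series" means these few. Any claim that something is new, unique, unknown or untested is made for them only; others in the source may bear on it.

Of the compounds shown here, three have been measured in an assay on Sf9 cells for inhibition of protein deacetylase HDAC6 (Homo sapiens), read by fluorescence; on this read-out lower numbers stand for stronger inhibition and higher numbers for weaker inhibition. Compound 1 `O=C(NO)c1ccc(Cn2nnc(-c3ncccn3)n2)cc1` gives 7 nM, and compound 3 `O=C(NO)c1ccc(Sc2nnc(-c3ccccc3)o2)cc1` gives 6 nM. Compound 2 `O=C(NO)c1ccc(Cc2nnc[nH]2)cc1` gives 198 nM, the highest number of the three and therefore the weakest inhibitor here, with both gaps beyond the scatter.

Compound 4 `NCc1ccc(C(=O)NO)cc1` has not yet been measured. Compared with compound 2 it carries amino in place of 4H-1,2,4-triazol-3-yl on a saturated chain carbon bound to an aromatic carbon. Within the data shown here, no measured pair shows this kind of change, so the step is a guess. Because compound 2 already stands at 198 nM and the 4H-1,2,4-triazol-3-yl ring is removed, compound 4 is expected to be weaker by a step beyond the scatter. For compound 4 the expected value is 800 nM, within 200 nM to 4000 nM, meaning a 4.0-fold higher number from compound 2 to compound 4 (0.61 log units; beyond the scatter).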

Compound 4, half-maximal inhibitory concentration: 695 nM
For compound 4 the middle estimate is 1.2-fold (0.06 log units) above the measured one; the range from low to high includes it.
By their numbers in this assay, from the lowest: compounds 3 and 1 (each within the scatter of the next); then compound 2; then compound 4.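

In this assay an amino group on a saturated chain carbon bound to an aromatic carbon, in place of 4H-1,2,4-triazol-3-yl, gives weaker inhibition (a 3.5-fold higher number from compound 2 to compound 4 (0.55 log units; beyond the scatter)). This first direct comparison at this position shows that the ring, though small, is better than amino here, with a modest step beyond the scatter. No available evidence bears on the cause of this difference.

The compounds shown leave open whether a hydroxyl group, a carboxylic acid or a phenyl ring on the same carbon would match the triazole. They also leave open whether its nitrogen atoms or simply its size matter.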